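Chalcone maleimides: swapping the para chloro for nitro

The compounds below may be only part of what the source reports. "The series", "measured", "known", "first", "only" and "open" are said of these compounds alone.

Measured compounds:
Compound 1, `O=C(/C=C/c1ccc(Cl)cc1)c1ccc(N2C(=O)C=CC2=O)cc1`: 7500 nM
Compound 2, `Cc1ccc(/C=C/C(=O)c2ccc(N3C(=O)C=CC3=O)cc2)cc1`: 2400 nM
Compound 3, `COc1ccc(/C=C/C(=O)c2ccc(N3C(=O)C=CC3=O)cc2)cc1OC`: 202000 nM

In a functional assay on MOLT-4 cells (Homo sapiens) for cytotoxicity (a higher number here means a weaker inhibitor, a lower number a stronger inhibitor), compound 1 stands second highest of the three numbers. Its nearest neighbour is compound 2, reached by a 3.1-fold lower number from compound 1 to compound 2 (0.49 log units; beyond the scatter). Compound 3 differs from compound 1 in more than one place, so its value is only set alongside: compound 3 gives 202000 nM against compound 1 with 7500 nM. Compound 4, `O=C(/C=C/c1ccc([N+](=O)[O-])cc1)c1ccc(N2C(=O)C=CC2=O)cc1`, has not yet been measured. It differs from compound 1 by nitro in place of chloro on an aromatic carbon. Among the compounds with values here, no measured step exchanges a chloro for a nitro, so only the single step from compound 1 to compound 2 bears on it, and that step shows that a change at this position moves this assay by a modest amount. Without a closer precedent, compound 4 is expected to land near compound 1, with a step of a 1.2-fold higher number from compound 1 to compound 4 (0.08 log units; within the scatter) in this assay, and the estimate for compound 4 is 9000 nM with a range from 2500 nM to 35000 nM.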

Compound 4, half-maximal inhibitory concentration: > 500000 nM
Compound 4 ended at the assay's limit; the forecaster's own chance of this, stated with the estimate: 5%; at least 55-fold (1.74 log units) between middle value and limit.
By their numbers in this assay, from the lowest: compound 2; then compound 1; then compound 3. At a limit, above all of these: compound 4.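

The aromatic carbon para to a large group proved far more sensitive in this assay than the exchange of chloro for methyl had suggested: nitro in place of chloro gave an at least 66-fold higher number from compound 1 to compound 4 (1.82 log units; beyond the scatter), and nitro in place of methyl gave an at least 200-fold higher number from compound 2 to compound 4 (2.31 log units; beyond the scatter). Compound 4 gave > 500000 nM, which is a limit of the assay and not a number: the limit of > 500000 nM in this assay, at which 1 of the 4 values shown sits. Chloro and methyl are therefore not a guide to every group at this carbon, since a single exchange here can produce a large step rather than a modest one.

The compounds shown leave open whether such a large step belongs to nitro alone or would also follow an amine or a carboxylic acid at this carbon. Nor do they tell what lies behind it.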